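The compounds below may be only part of what the source reports. "The series", "measured", "known", "first", "only" and "open" are said of these compounds alone.

Compound 2 `O=c1nc2oc(CCCCl)cc2cn1Cc1cn(-c2ccccc2F)nn1` gives 79800 nM in a functional assay on HepG2 cells (Homo sapiens) for antiproliferative activity, read by MTT assay, with a stated time of 72 h (on this read-out lower numbers stand for stronger inhibition and higher numbers for weaker inhibition), the only number shown in that read-out. In this assay compound 1 `CCCCCCc1cc2cn(Cc3cn(-c4ccccc4F)nn3)c(=O)nc2o1` gives > 100000 nM, which is a limit of the assay rather than a number. Going by the values given here, the one measured step, an at least 1.2-fold lower number from compound 1 to compound 2 (0.09 log units; that floor lies within the scatter), concerns a chloro in place of propyl on a saturated chain carbon and does not touch the group that changes here. Compound 3 `O=c1nc2oc(CCCCl)cc2cn1Cc1cn(-c2ccc(F)cc2)nn1` differs from compound 2 by 4-fluorophenyl in place of 2-fluorophenyl on an aromatic nitrogen. Among the compounds with values here, with no measured step bearing on this change, no step beyond the scatter is expected in this assay; the expected step is a 1.0-fold higher number from compound 2 to compound 3 (0.00 log units; within the scatter). Compound 3 is therefore estimated at 80000 nM, within 30000 nM to 200000 nM.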

Compound 3, half-maximal inhibitory concentration: 14600 nM
Compound 3: middle estimate off by 5.5-fold (0.74 log units), on the high side; the measured number lies below the stated range.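

In this assay, 4-fluorophenyl in place of 2-fluorophenyl on the aromatic nitrogen gives a 5.5-fold lower number from compound 2 to compound 3 (0.74 log units; beyond the scatter), so this position responds to where the fluorine sits on the phenyl ring, although both groups have the same atom counts. The earlier step, whose floor lay within the scatter, showed no clear change in either direction. Nothing measured here accounts for this step. The compounds shown leave open how an unsubstituted phenyl or a benzyl group would read at this nitrogen, and whether the step would hold with the longer chain of compound 1.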